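Cyclopentyl replaces the aryl group on the alkyne

The compounds below may be only part of what the source reports. "The series", "measured", "known", "first", "only" and "open" are said of these compounds alone.

Within the data shown here, compound 1 `Cc1ccccc1C#Cc1ccc(C(=O)N[C@H](C)C(C)(C)O)nc1` gives 59.9% in a functional assay on HEK293 cells for positive allosteric modulation of metabotropic glutamate receptor 5 (Rattus norvegicus), read by fluorescence and calcium flux (a lower number here means a smaller maximal response, a higher number a larger maximal response), the lower of the two numbers known here. Among the measured compounds shown here, compound 2 `C[C@@H](NC(=O)c1ccc(C#Cc2cccnc2)cn1)C(C)(C)O` gives 71.5%, and the step of a number 11.6 percentage points higher from compound 1 to compound 2 (beyond the scatter) is the only measured change at the same place. Compound 3 `C[C@@H](NC(=O)c1ccc(C#CC2CCCC2)cn1)C(C)(C)O` differs from compound 1 by cyclopentyl in place of 2-methylphenyl on a triple-bonded carbon. That one step bears on this change only loosely, since it exchanged one aromatic ring for another. No change beyond the scatter is therefore expected, with a step of a number 0.1 percentage points higher from compound 1 to compound 3 (within the scatter). For compound 3 the estimate is 60%, between 40% and 80%.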

Compound 3, largest response reached (reported as efficacy), in percent of the reference or control that the assay uses: 63.7%
The estimate for compound 3 lay 3.7 percentage points below the measured number, and the stated range covers the measured number.
By their numbers in this assay, from the lowest: compounds 1, 3 and 2 (each within the scatter of the next, the first and the last beyond it).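

In this assay, the response does not depend on an aromatic ring on the triple-bonded carbon: cyclopentyl gives a number 3.8 percentage points higher from compound 1 to compound 3 (within the scatter) and, set against pyridin-3-yl, a number 7.8 percentage points lower from compound 2 to compound 3 (within the scatter). Compound 3 thus stays within the scatter of both aromatic compounds, although those two differ from each other beyond it. Nothing available here gives a reason for this result.

Still open, from the compounds shown here alone, is whether a smaller ring such as cyclopropyl would hold this response on the triple-bonded carbon. The same applies to a longer chain such as n-butyl, or to a ring carrying an amine, such as piperidin-4-yl.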